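The source may report more compounds than this note shows. Statements on the series, on what has been measured and on what is new or still open speak of the compounds shown alone.

Three compounds of this set have been measured in an assay on HEK293 cells for inhibition of Steryl-sulfatase (Homo sapiens), tested at 1 uM; on this read-out higher numbers stand for a stronger effect at the one concentration tested and lower numbers for a weaker effect:

Compound 1, `NS(=O)(=O)Oc1ccc2c(c1)CN(C(=O)c1ccc(N3CCN(Cc4ccccc4)CC3)cc1)CC2`, gives 75.8%.
Compound 2, `CCN(Cc1cccnc1)c1ccc(C(=O)N2CCc3ccc(OS(N)(=O)=O)cc3C2)cc1`, gives 85.2%.
Compound 3, `CN(C)CCN(CCN(C)C)c1cccc(C(=O)N2CCc3ccc(OS(N)(=O)=O)cc3C2)c1`, gives 17.1%.

All three share the same core and differ only in the amine-bearing aromatic portion attached through the amide. Among the three numbers compound 2 stands at the upper end. Compound 1 sits within the usual scatter of it, so the two cannot be told apart, while compound 3 lies far below and clearly beyond the scatter.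

Compound 4, `CCCN(CCC)c1ccc(C(=O)N2CCc3ccc(OS(N)(=O)=O)cc3C2)cc1`, has not yet been measured in this assay. It differs from compound 2 in one place: dipropylamino in place of ethyl((pyridin-3-yl)methyl)amino on an aromatic carbon.

For the measured compounds named here, no step between two measured compounds isolates this kind of change, so the expectation rests on the whole set. Compound 1 carries a different amino group at the same place and gives 75.8%, close to compound 2. Compound 3, with its amino group on another carbon of that ring, gives 17.1%. Because compound 1 gives 75.8% with another amine at that position, only a modest downward step, or none beyond the scatter, is expected from compound 2 to compound 4, a number 11.2 percentage points lower from compound 2 to compound 4 (beyond the scatter). Compound 4 is therefore estimated at 74%, with a range from 50% to 92%.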

Compound 4, a percentage reported as inhibition, at one concentration (the size of the read-out at that concentration, not a potency): 84.7%
Beside the measured number, compound 4's estimate is 10.7 percentage points below it; the measured number falls inside the stated range.
By their numbers in this assay, from the lowest: compound 3; then compounds 1, 4 and 2 (each within the scatter of the next).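

In this assay, for the compounds shown here, replacing ethyl((pyridin-3-yl)methyl)amino with dipropylamino on an aromatic carbon gives a number 0.5 percentage points lower from compound 2 to compound 4 (within the scatter), and this is the first comparison in the set that changes this group alone. The group that leaves contains a six-membered aromatic ring with one hetero atom, whereas the group that enters has no ring and is smaller, so that ring is not needed for this level of inhibition at the one concentration tested. The position therefore accepts two quite different amino groups without a change that can be told from the scatter, although nothing shown explains why they read alike.

A reading at one concentration is not a potency, so compound 2 and compound 4 could still differ when tested across a range of concentrations. On these data alone, it also remains open how far this tolerance extends: diethylamino or dibutylamino would test the length of the chains, piperidine would tie them into a ring, and a carboxylic acid would replace the amine altogether.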